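The source may hold more compounds than are shown below. What is called first, only, known or untested is meant among the compounds shown, and "the series" means these compounds.

Working notes on the series. Within the data shown here, in an assay on isolated protein for binding affinity to melanin-concentrating hormone receptor 1 (Homo sapiens) (a higher number here means a weaker inhibitor, a lower number a stronger inhibitor), compound 3 `Cc1ccc(-c2cc3ncn([C@H]4CCN(C(=O)N(C)[C@H]5CCN(C)C5)C4)c(=O)c3s2)cc1` gives 15 nM, the second highest of the three numbers so far. Compound 1 `CN(C(=O)N1CC[C@H](n2cnc3cc(-c4ccc(Cl)cc4)sc3c2=O)C1)[C@H]1CCN(CC2CCCCC2)C1` gives 50 nM in this assay, and compound 2 `CN(C(=O)N1CC[C@H](n2cnc3cc(-c4ccc(Cl)cc4)sc3c2=O)C1)[C@H]1CCN(CC2CCOC2)C1` gives 4 nM. Among the measured compounds shown here, the only single-point step measured, a 13-fold lower number from compound 1 to compound 2 (1.10 log units; beyond the scatter), concerns the group on the amine nitrogen in the ring, not the aryl group on the core. Compound 4 `CN1CC[C@H](N(C)C(=O)N2CC[C@H](n3cnc4cc(-c5ccc6c(c5)OCCO6)sc4c3=O)C2)C1` differs from compound 3 by 2,3-dihydro-1,4-benzodioxin-6-yl in place of 4-methylphenyl on an aromatic carbon. For the measured compounds named here, no measured step bears on this change; the series gives no guidance on the aryl side of the core. The step from compound 3 to compound 4 in this assay is therefore expected to be small, no change at the digits printed from compound 3 to compound 4 (within the scatter), with no direction beyond the scatter. Compound 4 is expected to give about 15 nM in this assay, within 4 nM to 55 nM.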

Compound 4, inhibition constant: 143 nM
Compound 4: middle estimate off by 9.5-fold (0.98 log units), on the low side; measured number outside the range, above it.
By their numbers in this assay, from the lowest: compound 2; then compound 3; then compound 1; then compound 4.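

In this assay, the aryl group on the aromatic carbon next to the ring sulfur proves not to be interchangeable, with a 9.5-fold higher number from compound 3 to compound 4 (0.98 log units; beyond the scatter) on 2,3-dihydro-1,4-benzodioxin-6-yl replacing 4-methylphenyl. Among these compounds, this is the first measured step on the aryl side of the core, and the position, like the group on the amine nitrogen in the ring, can move the number beyond the scatter. Nothing available accounts for this step.

Open, as far as these compounds go, is whether a 4-methoxyphenyl or unsubstituted phenyl group at this position stays close to compound 3, and whether the same change costs as much with an oxolan-3-yl group on the saturated chain carbon.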